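Working notes: the step from compound 3 to compound 4

The source may hold more compounds than are shown below. What is called first, only, known or untested is meant among the compounds shown, and "the series" means these compounds.

Measured so far in a functional assay on HepG2 cells (Homo sapiens) for antiproliferative activity, read by MTT assay, with a stated time of 48 h; on this read-out lower numbers stand for stronger inhibition and higher numbers for weaker inhibition:
compound 1 `CCCCc1ccc2c(c1)C(=O)C(=O)N2` gives only a limit, > 10000 nM.
compound 2 `Cc1ccc(-c2ccc3c(c2)C(=O)C(=O)N3)cc1` gives 6000 nM.
compound 3 `CCN1C(=O)C(=O)c2cc(-c3ccc(OC)cc3)ccc21` gives 4470 nM.

Compound 3 holds the lowest of the two numbers in this assay, but compound 2 sits within the usual scatter of it, so no order between the two is claimed. The value of compound 1 is a limit, not a number (the limit of > 10000 nM in this assay, at which 1 of the 3 values shown sits).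

Compound 4 `COc1ccc(-c2ccc3c(c2)C(=O)C(=O)N3Cc2ccc(F)cc2)cc1` differs from compound 3 by 4-fluorophenyl in place of methyl on a saturated chain carbon bound to an amide-type nitrogen in a ring. Among the compounds with values here, no step between measured compounds touches this position, so no measured guide to the size of the change exists. A moderate move toward stronger inhibition is expected, with wide uncertainty: compound 4 is estimated at 2000 nM, between 500 nM and 8000 nM, a step of a 2.2-fold lower number from compound 3 to compound 4 (0.35 log units; beyond the scatter).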

Compound 4, half-maximal inhibitory concentration: 1120 nM
Estimate against measurement, compound 4: 1.8-fold (0.25 log units) above; the range from low to high includes it.
By their numbers in this assay, from the lowest: compound 4; then compounds 3 and 2 (each within the scatter of the next). At a limit, above all of these: compound 1.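

In this assay, within the data shown here, the saturated chain carbon bound to an amide-type nitrogen in a ring proves open to change: 4-fluorophenyl in place of methyl gives a 4.0-fold lower number from compound 3 to compound 4 (0.60 log units; beyond the scatter) and this is the first step read at this position. An added aromatic ring is therefore compatible with antiproliferative activity here, and the number falls rather than rises. Nothing at hand accounts for the size of this step.

Whether the ring alone or its fluorine carries the step stays open, since plain benzyl is absent from the compounds shown. Going by these compounds, a longer alkyl chain or an amine at this position also remains untested by these data.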